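The source may hold more compounds than are shown below. What is called first, only, known or untested is meant among the compounds shown, and "the series" means these compounds.

Working notes on the series. Within the data shown here, the shared core carries two aryl groups, and the three compounds measured so far differ only in the substituents on those rings. Compound 1 `Fc1ccc(-c2cc(-c3ccccc3)n[nH]2)cc1` gives 4070 nM in an assay on mitochondria from brain for inhibition of Amine oxidase [flavin-containing] A (Bos taurus), read by fluorescence; a higher number here means a weaker inhibitor, a lower number a stronger inhibitor. Among the measured compounds shown here, compound 2 `Fc1ccc(-c2cc(-c3ccc(Cl)cc3)n[nH]2)cc1` gives 3.02 nM, and the single step from compound 1 to compound 2 a 1300-fold lower number from compound 1 to compound 2 (3.13 log units; beyond the scatter) is the only one-point change measured in the set. Compound 3 `Cc1ccc(-c2cc(-c3ccc(Cl)cc3)[nH]n2)cc1` gives 3020 nM; it stands second highest of the three numbers, within the scatter of compound 1 and far from compound 2.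

Compound 4 `Cc1ccc(-c2cc(-c3ccc(F)cc3)[nH]n2)cc1` is not yet measured. It differs from compound 3 by fluoro in place of chloro on an aromatic carbon. For the measured compounds named here, no measured step exchanges chloro for fluoro directly; the step from compound 1 to compound 2 bears on it only indirectly, as it shows what the presence of chloro on that ring is worth against hydrogen, and it was large. Compound 3, however, already sits at a high number despite carrying chloro, so the room for a further rise is modest. For compound 4 a moderate upward step a 2.6-fold higher number from compound 3 to compound 4 (0.42 log units; beyond the scatter) is expected, with no strong confidence. The estimate for compound 4 in this assay is 8000 nM, between 2000 nM and 40000 nM.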

Compound 4, half-maximal inhibitory concentration: 2290 nM
Estimate against measurement, compound 4: 3.5-fold (0.54 log units) above, within the range that was stated.
By their numbers in this assay, from the lowest: compound 2; then compounds 4, 3 and 1 (each within the scatter of the next).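

With methyl on the other ring, fluoro and chloro at this place, on an aromatic carbon para to a large group, cannot be told apart: a 1.3-fold lower number from compound 3 to compound 4 (0.12 log units; within the scatter). With fluoro on the other ring, the same place separates chloro sharply from methyl, a 760-fold higher number from compound 2 to compound 4 (2.88 log units; beyond the scatter), whereas methyl and hydrogen cannot be told apart, a 1.8-fold lower number from compound 1 to compound 4 (0.25 log units; within the scatter), so among these compounds only chloro in compound 2 stands clear of the rest, and compounds 1, 3 and 4 form one group at high numbers. Nothing measured alongside these numbers accounts for the large step or for the absence of a step between fluoro and chloro.

The compounds shown leave open whether a bromo, a methoxy or an amine at this place would read like the chloro of compound 2 or like the methyl of compound 4. Also open, going by these compounds, is how far the group on the other ring governs what chloro is worth, since compound 3 carries chloro and still gives 3020 nM.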